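The source may report more compounds than this note shows. Statements on the series, on what has been measured and on what is new or still open speak of the compounds shown alone.

Working notes on the series. The shared core carries two benzyloxy groups and a hydrazone chain; compound 1 `N/N=C\c1cc(=O)oc2cc(OCc3ccccc3)cc(OCc3ccccc3)c12` bears hydrogen on the amine nitrogen and in a functional assay, read by spectrophotometry, with a stated time of 5 min (on this read-out higher numbers stand for weaker inhibition and lower numbers for stronger inhibition), compound 1 gives 36500 nM. Compound 2 `O=c1cc(/C=N\Nc2ccccc2)c2c(OCc3ccccc3)cc(OCc3ccccc3)cc2o1` bears phenyl there and in this assay compound 2 gives 303000 nM. Within the data shown here, the only one-place step so far, an 8.3-fold higher number from compound 1 to compound 2 (0.92 log units; beyond the scatter), is the replacement of hydrogen by phenyl on the amine nitrogen. On the numbers seen, compound 2 stands at the highest value of the two, with compound 1 the nearest at the lower end.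

Compound 3 `O=c1cc(/C=N\Nc2ccc([N+](=O)[O-])cc2[N+](=O)[O-])c2c(OCc3ccccc3)cc(OCc3ccccc3)cc2o1` changes that phenyl: 2,4-dinitrophenyl in place of phenyl on an amine nitrogen. Among the measured compounds shown here, no measured step covers a substituent on the phenyl itself; the one step that bears on the site, the hydrogen-to-phenyl change, was modest in size and moved toward weaker inhibition. Without a precedent for substitution of the ring, only a small step is expected for a 1.5-fold lower number from compound 2 to compound 3 (0.18 log units; within the scatter), in either direction and possibly none beyond the scatter. Compound 3 is therefore estimated at 200000 nM in this assay, with a range of 50000 nM to 800000 nM.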

Compound 3, half-maximal inhibitory concentration: 292000 nM
The estimate for compound 3 lay 1.5-fold (0.16 log units) below the measured number; low and high end bracket the measured number.
By their numbers in this assay, from the lowest: compound 1; then compounds 3 and 2 (each within the scatter of the next).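

In this assay, 2,4-dinitrophenyl in place of phenyl on the amine nitrogen gives a 1.0-fold lower number from compound 2 to compound 3 (0.02 log units; within the scatter), so the two nitro groups do not separate the ring-bearing compounds on this read-out. Set against hydrogen on the same nitrogen, 2,4-dinitrophenyl gives an 8.0-fold higher number from compound 1 to compound 3 (0.90 log units; beyond the scatter), so the shift toward weaker inhibition first seen with phenyl now appears with a second ring, and among the three compounds shown it goes with an aromatic ring on that nitrogen, with or without nitro groups, and none goes against it. No measurement at hand gives a reason for this pattern.

On these data alone, it remains open whether a methyl or a benzyl on the amine nitrogen would give a number that falls with hydrogen or with the two aromatic rings. As far as these compounds go, it is equally open whether a single nitro group, a methoxy or a carboxylic acid on the phenyl would give a number beyond the scatter of compound 2, and whether the two benzyloxy groups of the shared core could be replaced by hydroxyl or methoxy without a shift on this read-out.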